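The compounds below may be only part of what the source reports. "The series", "measured", "known", "first", "only" and "open" are said of these compounds alone.

In a physicochemical assay for lipophilicity (on this read-out higher numbers stand for higher lipophilicity and lower numbers for lower lipophilicity), compound 3 `C[C@H]1CC[C@@H]2[C@@H](OC(=O)[C@]23CC(c2ccc(Br)cc2)N(c2ccccc2)O3)[C@]2(C)C(=O)C=C[C@@]12O` gives 4, the highest of the three numbers, ahead of compound 1 `C[C@H]1CC[C@@H]2[C@@H](OC(=O)[C@]23CC(c2ccccc2Br)=NO3)[C@]2(C)C(=O)C=C[C@@]12O` at 2.22 and compound 2 `C[C@H]1CC[C@@H]2[C@@H](OC(=O)[C@]23CC(c2ccccc2F)=NO3)[C@]2(C)C(=O)C=C[C@@]12O` at 1.58. Compound 4 `Cc1ccc(C2C[C@@]3(ON2c2ccccc2)C(=O)O[C@@H]2[C@H]3CC[C@H](C)[C@]3(O)C=CC(=O)[C@@]23C)cc1` differs from compound 3 by methyl in place of bromo on an aromatic carbon, with 4-bromophenyl becoming 4-methylphenyl. Among the measured compounds shown here, only one measured step bears on this change: a number 0.64 log units lower from compound 1 to compound 2 (beyond the scatter), a modest step with fluoro in place of bromo on an aromatic carbon. For the measured compounds named here, that step has a different entering group and a different surrounding structure, and no step with methyl entering has been measured. A slight fall in this assay is therefore expected, with nothing beyond the scatter. The estimate for compound 4 is 3.8, with an expected range of 3.4 to 4.2. This estimate means an expected a number 0.20 log units lower from compound 3 to compound 4 (within the scatter).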

Compound 4, partition coefficient: 3.64
For compound 4 the middle estimate is 0.16 log units above the measured one; measured number inside the range.
By their numbers in this assay, from the lowest: compound 2; then compound 1; then compound 4; then compound 3.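

In this assay, methyl in place of bromo gives a number 0.36 log units lower from compound 3 to compound 4 (beyond the scatter), so this change on an aromatic carbon, para to a large group, now has a measured step of its own. It is the only step shown with methyl entering, and it stands on the core of compound 3, not on that of compound 1. Nothing measured here accounts for the step. Open, as far as these compounds go, is how an amine or a carboxylic acid in place of bromo at this position would read in this assay. Also open, from the compounds shown here alone, is whether methyl in place of bromo gives a similar step on the core of compound 1.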